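A few compounds are considered here, and "the series" means these few. Any claim that something is new, unique, unknown or untested is made for them only; others in the source may bear on it.

Measured compounds:
- compound 1, `CN(C)CCCC1(c2ccc(F)cc2)OCc2cc(-c3cccc(C#N)c3)ccc21`: in an assay on Caudate-putamen for displacement of a labelled ligand from sodium-dependent dopamine transporter (Rattus norvegicus), read by scintillation counting (a lower number here means a stronger inhibitor, a higher number a weaker inhibitor), compound 1 gives 737 nM
- compound 2, `COc1cccc(-c2ccc3c(c2)COC3(CCCN(C)C)c2ccc(F)cc2)c1`: in this assay compound 2 gives "not determined" (no result reported)
- compound 3, `CN(C)CCCC1(c2ccc(F)cc2)OCc2cc(-c3cccc(F)c3)ccc21`: in this assay compound 3 gives "not determined" (no result reported)

Going by the values given here, compound 1 therefore stands as the only entry with a number; the two further entries carry no value, so no comparison across the series can be drawn and no measured step exists between any pair of compounds.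

The next compound, compound 4, `CN(C)CCCC1(c2ccc(F)cc2)OCc2cc(-c3cccc(Cl)c3)ccc21`, keeps the shared core of compound 1 and differs from it in one place: chloro in place of cyano on an aromatic carbon. Among the compounds with values here, nothing shows how this change is rewarded or punished in this assay, since no other pair differs in the same way.

Within the data shown here, with no measured step to lean on, the expectation rests on the change alone. The swap is small in atom count and removes the one hydrogen-bond acceptor of the leaving group, and such a swap is expected to move this assay only modestly, most likely within the scatter or slightly toward a lower value. Compound 4 is estimated at 500 nM, with a range of 150 nM to 1600 nM, which means an expected step of a 1.5-fold lower number from compound 1 to compound 4 (0.17 log units; within the scatter).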

Compound 4, inhibition constant: 1390 nM
For compound 4 the middle estimate is 2.8-fold (0.44 log units) below the measured one, and the stated range covers the measured number.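

Going by these compounds alone, the first measured step at this place, on an aromatic carbon meta to a large group, is 3-cyanophenyl to 3-chlorophenyl: in this assay, chloro in place of cyano gives a 1.9-fold higher number from compound 1 to compound 4 (0.28 log units; within the scatter). Compound 1 and compound 4 therefore cannot be told apart in this assay, even though the cyano group leaving carries a hydrogen-bond acceptor and the chloro group entering carries none, so this single pair shows no measurable dependence on that difference. No measurement available here explains this result or links it to any property of either group.

Steps involving compound 2 and compound 3 cannot be read, so this pair remains the only comparison at this place and supports no trend across substituents. Still open, as far as these compounds go, is how this assay would read with a carboxylic acid, a primary amine or a longer chain at the same place, and whether any of these would give a step beyond the scatter.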